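Chloro for Methyl on Compound 1

A few compounds are considered here, and "the series" means these few. Any claim that something is new, unique, unknown or untested is made for them only; others in the source may bear on it.

In a functional assay on HCT-15 cells (Homo sapiens) for cytotoxicity, in the presence of a further agent that is not named here (a higher number here means a weaker inhibitor, a lower number a stronger inhibitor), compound 1 (`Cc1cccc(-c2cc(-c3ccc(Cl)o3)cc(-c3ccsc3)n2)c1`) gives 21700 nM, second highest of three numbers. Compound 3 (`Clc1ccc(-c2cc(-c3ccoc3)cc(-c3cccs3)n2)cc1`) gives 50000 nM and compound 2 (`Clc1ccc(-c2cc(-c3cccs3)nc(-c3ccccc3Cl)c2)o1`) gives 6190 nM, both gaps beyond the scatter. Compound 4 (`Clc1cccc(-c2cc(-c3ccc(Cl)o3)cc(-c3ccsc3)n2)c1`) differs from compound 1 by chloro in place of methyl on an aromatic carbon. Within the data shown here, no measured pair isolates this change. Compound 2 and compound 3 both carry chloro on a six-membered aromatic ring of carbon only, yet their values lie far apart, so they set no direction. In this assay only a small step toward a lower number is expected, within the scatter. For compound 4 the estimated value is 15000 nM, with a range of 5000 nM to 45000 nM. The expected change is a 1.4-fold lower number from compound 1 to compound 4 (0.16 log units; within the scatter).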

Compound 4, half-maximal inhibitory concentration: 13700 nM
The estimate for compound 4 lay 1.1-fold (0.04 log units) above the measured number; the range from low to high includes it.
By their numbers in this assay, from the lowest: compound 2; then compounds 4 and 1 (each within the scatter of the next); then compound 3.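

Among these compounds, the first direct reading of this change at this place, a six-membered aromatic ring of carbon only, gives a 1.6-fold lower number from compound 1 to compound 4 (0.20 log units; within the scatter) in this assay. Among the compounds shown here, on the core of compound 1, then, 3-methylphenyl and 3-chlorophenyl cannot be told apart in this assay, something no earlier pair could show. Nothing available here accounts for this result.

From the compounds shown here alone, whether an amine, a methoxy group or a carboxylic acid at this place would also leave the number within the scatter stays open. So does whether this change would read the same on a different core.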